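This account rests on a few compounds, and the source may have more. Where it says the series, first, only, none or still open, it means among the compounds named here.

Compound 2, `CCCCCCOc1ccc2c(NCCN(C)C)ccnc2c1`, stands lowest of the three measured numbers in a functional assay on NCI-H1650 cells (Homo sapiens) for cytotoxicity, read by MTT assay, with a stated time of 48 h (a higher number here means a weaker inhibitor, a lower number a stronger inhibitor), with 930 nM. Compound 1, `CCCCCCOc1ccc2c(Cl)ccnc2c1`, gives 2080 nM, and the step of a 2.2-fold lower number from compound 1 to compound 2 (0.35 log units; beyond the scatter). Compound 3, `CCOc1ccc2c(Cl)ccnc2c1`, gives 3340 nM, and the step of a 1.6-fold higher number from compound 1 to compound 3 (0.21 log units; within the scatter). Compound 4, `CN(C)CCNc1ccnc2cc(OCc3ccc(F)cc3)ccc12`, differs from compound 2 by 4-fluorophenyl in place of pentyl on a saturated chain carbon bound to an oxygen on an aromatic ring. Among the compounds with values here, only the step from compound 1 to compound 3 touches the chain on that oxygen, and it stayed within the scatter, so the chain seems to tolerate change there; the amine side of compound 2 is kept. Compound 4 is therefore expected to show a 1.2-fold lower number from compound 2 to compound 4 (0.07 log units; within the scatter), a step not clearly beyond the scatter. Compound 4 is estimated at 800 nM, within 300 nM to 2500 nM.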

Compound 4, half-maximal inhibitory concentration: 780 nM
Estimate against measurement, compound 4: 1.0-fold (0.01 log units) above, within the range that was stated.
By their numbers in this assay, from the lowest: compounds 4 and 2 (each within the scatter of the next); then compounds 1 and 3 (each within the scatter of the next).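

In this assay, the step of a 1.2-fold lower number from compound 2 to compound 4 (0.08 log units; within the scatter) shows that with the amine side kept, hexyl and 4-fluorobenzyl on the oxygen cannot be told apart. The earlier step at this position only compared two saturated chains on chloro compounds, whereas this one brings in an aromatic ring on compounds that carry the amine side. Nothing at hand bears on this result.

The compounds shown leave open whether a plain benzyl or a 4-methoxybenzyl group on that oxygen would give a similar number. They also leave open how a morpholine in place of the dimethylamino group would read.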